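Swapping the Ring Nitrogen Substituent in a Shared Core

The source may hold more compounds than are shown below. What is called first, only, known or untested is meant among the compounds shown, and "the series" means these compounds.

Compound 2 `CC(=O)N1CCC(n2c(-c3ccc(OCc4c(-c5c(Cl)cccc5Cl)noc4C(C)C)cc3)nc3ccc(C(=O)O)cc32)CC1` is recorded as "not determined" (no result reported) in an assay on isolated protein for agonist activity at Bile acid receptor (Homo sapiens), read by TR-FRET (a higher number here means that more compound is needed for the effect, a lower number that less compound is needed), so it stands nowhere on the numbers shown. Two related compounds do: compound 1 `CCC(CC)n1c(-c2ccc(OCc3c(-c4c(Cl)cccc4Cl)noc3C(C)C)cc2)nc2ccc(C(=O)O)cc21` gives 26.5 nM in this assay, and compound 3 `CCC(CC)n1c(-c2ccc(OCc3c(-c4c(Cl)cccc4Cl)noc3C(C)C)cc2Cl)nc2ccc(C(=O)O)cc21` gives 21.6 nM. Among the measured compounds shown here, the only single-point step, a 1.2-fold lower number from compound 1 to compound 3 (0.09 log units; within the scatter), concerns a chloro on an aromatic carbon and tells nothing about the substituent on the aromatic nitrogen. Compound 4 `CC(C)c1onc(-c2c(Cl)cccc2Cl)c1COc1ccc(-c2nc3ccc(C(=O)O)cc3n2Cc2ccc(F)cc2)cc1` differs from compound 2 by 4-fluorobenzyl in place of 1-acetylpiperidin-4-yl on an aromatic nitrogen. For the measured compounds named here, no measured step bears on this change, and compound 2 itself has no value, so any expectation can rest only on the two measured compounds that share the core. Compound 4 is therefore expected to come out in this assay near 30 nM, estimated between 8 nM and 120 nM.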

Compound 4, half-maximal effective concentration: 105 nM
Beside the measured number, compound 4's estimate is 3.5-fold (0.54 log units) below it, and the stated range covers the measured number.
By their numbers in this assay, from the lowest: compounds 3 and 1 (each within the scatter of the next); then compound 4.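

At the aromatic nitrogen, 4-fluorobenzyl in place of pentan-3-yl brings a 4.0-fold higher number from compound 1 to compound 4 (0.60 log units; beyond the scatter) in this assay. This step lies beyond the scatter, so the group on this nitrogen moves the number, whereas the chloro on the aromatic carbon left it within the scatter. Nothing given here explains the shift. Going by these compounds, whether a plain benzyl without the fluorine or a cyclohexyl would stand nearer compound 1 or compound 4 remains open. Where a group with a ring nitrogen, such as 1-acetylpiperidin-4-yl, falls on these numbers also remains open.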